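A few compounds are considered here, and "the series" means these few. Any claim that something is new, unique, unknown or untested is made for them only; others in the source may bear on it.

Compound 1 `c1csc(-c2ccccc2NCC2=NCCN2)c1` gives in a functional assay for activation of Alpha-1D adrenergic receptor (Homo sapiens) (on this read-out higher numbers stand for an effect only at larger amounts of compound and lower numbers for an effect already at smaller amounts), a value of 18.2 nM. Compound 2 `Cc1nc(-c2ccccc2NCC2=NCCN2)co1` is recorded in this assay only as a limit, < 5020 nM, so where it truly stands is not known. The step that the limit leaves unreadable from compound 1 to compound 2 therefore cannot be read, which the limit of < 5020 nM in this assay, at which 1 of the 2 values shown sits, shows. Compound 3 `Cc1nc(-c2ccccc2NCC2=NCCN2)no1` differs from compound 2 by 5-methyl-1,2,4-oxadiazol-3-yl in place of 2-methyl-1,3-oxazol-4-yl on an aromatic carbon. Among the measured compounds shown here, no measured step bears on this change, and the one measured step is unreadable, so the step that is expected here is a step that the limit leaves unreadable from compound 2 to compound 3, resting on little. Compound 3 is estimated at 800 nM, expected between 100 nM and 5000 nM.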

Compound 3, half-maximal effective concentration: < 5020 nM
Compound 3 was reported as a limit; the forecaster's own chance of this, stated with the estimate: 35%; the middle value is on the limit's open side.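

Compound 3 is recorded only as a limit, so no new step from compound 1 or compound 2 to compound 3 can be read in this assay: the limit of < 5020 nM in this assay, at which 2 of the 3 values shown sit.

The compounds shown leave open where compound 2 and compound 3 truly stand, and how 2-methyl-1,3-oxazol-4-yl and 5-methyl-1,2,4-oxadiazol-3-yl compare with thiophen-2-yl or with each other.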